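The source may report more compounds than this note shows. Statements on the series, on what has been measured and on what is new or still open speak of the compounds shown alone.

In an ADME assay on microsomes from liver (Mus musculus) for metabolic stability (on this read-out higher numbers stand for a longer-lived compound and lower numbers for a shorter-lived compound), compound 3 `Cc1nc(C(c2ccc(-c3ccc4cccc(F)c4c3)[nH]c2=O)C(C)C)[nH]c1C` gives 0.0817 h, the lowest of the two numbers in hand. Compound 2 `CC(C)C(c1ccc(-c2ccc3cccc(F)c3c2)[nH]c1=O)N1CCN/C1=N\C#N` gives 0.207 h, and the step of a 2.5-fold lower number from compound 2 to compound 3 (0.40 log units; beyond the scatter) lies beyond the scatter. Compound 1 `CC(C)C(c1ncc[nH]1)c1ccc(-c2ccc3cccc(F)c3c2)[nH]c1=O` gives < 0.0667 h, which is a limit of the assay. The step of an at least 3.1-fold higher number from compound 1 to compound 2 (0.49 log units; beyond the scatter) is at least modest, whereas an at least 1.2-fold higher number from compound 1 to compound 3 (0.08 log units; that floor lies within the scatter) has a floor within the scatter. Compound 4 `CC(C)C(c1cnc(N)s1)c1ccc(-c2ccc3cccc(F)c3c2)[nH]c1=O` differs from compound 3 at the same place: 2-amino-1,3-thiazol-5-yl in place of 4,5-dimethyl-1H-imidazol-2-yl on a saturated chain carbon bound to an aromatic carbon and a saturated chain carbon. Both compounds bearing a five-membered aromatic ring with 2 hetero atoms at this position stay close, as the step of an at least 1.2-fold higher number from compound 1 to compound 3 (0.08 log units; that floor lies within the scatter) shows, so for compound 4 the expected step of a 1.0-fold lower number from compound 3 to compound 4 (0.01 log units; within the scatter) is none beyond the scatter. Compound 4 is therefore estimated at 0.08 h, ranging from 0.04 h to 0.2 h.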

Compound 4, half-life: 0.08 h
For compound 4 middle estimate and measured number coincide at the digits printed, and the stated range covers the measured number.
By their numbers in this assay, from the lowest: compounds 4 and 3 (each within the scatter of the next); then compound 2. At a limit, below all of these: compound 1.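

In this assay, 2-amino-1,3-thiazol-5-yl in place of 4,5-dimethyl-1H-imidazol-2-yl gives a 1.0-fold lower number from compound 3 to compound 4 (0.01 log units; within the scatter), so the two groups are not told apart here. The gap to the five-membered non-aromatic group persists against this different aromatic ring, with a 2.6-fold lower number from compound 2 to compound 4 (0.41 log units; beyond the scatter) as the step. Compound 1 is held at a limit: the limit of < 0.0667 h in this assay, at which 1 of the 4 values shown sits. The step of an at least 1.1-fold higher number from compound 1 to compound 4 (0.07 log units; that floor lies within the scatter) gives only a floor, so its size cannot be read.

On these data alone, whether the higher number of compound 2 belongs to its non-aromatic ring or to its nitrile stays open. As far as these compounds go, how a saturated amine or a carboxylic acid would read at this place also stays open.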